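The source may hold more compounds than are shown below. What is called first, only, known or untested is meant among the compounds shown, and "the series" means these compounds.

Compound 1 `COc1cc(-c2nnc3c(OC(C)C)cc(-c4ccc5[nH]ccc5c4)cn23)cc(OC)c1OC` is the reference point. In a functional assay on HeLa cells (Homo sapiens) for antiproliferative activity, read by MTT assay, with a stated time of 48 h (a higher number here means a weaker inhibitor, a lower number a stronger inhibitor), compound 1 gives 261 nM. Compound 2 `COc1cc(-c2nnc3c(OC4COC4)cc(-c4ccc5[nH]ccc5c4)cn23)cc(OC)c1OC` carries oxetan-3-yl in place of isopropyl on an oxygen on an aromatic ring, and in this assay compound 2 gives 2780 nM; this change gave an 11-fold higher number from compound 1 to compound 2 (1.03 log units; beyond the scatter). Compound 3 `COc1cc(-c2nnc3c(OC(C)C)cc(-c4ccc5c(ccn5C)c4)cn23)cc(OC)c1OC` differs from compound 1 by methyl in place of hydrogen on an aromatic nitrogen, and in this assay compound 3 gives 503 nM, a step of a 1.9-fold higher number from compound 1 to compound 3 (0.28 log units; within the scatter). Compound 4 `COc1cc(-c2nnc3c(OC4COC4)cc(-c4ccc5c(ccn5C)c4)cn23)cc(OC)c1OC` has not yet been measured; it differs from compound 3 by oxetan-3-yl in place of isopropyl on an oxygen on an aromatic ring, the same change that separates compound 1 from compound 2, made at the same place. Because that change produced an 11-fold higher number from compound 1 to compound 2 (1.03 log units; beyond the scatter), a step of similar size is expected from compound 3, namely an 8.9-fold higher number from compound 3 to compound 4 (0.95 log units; beyond the scatter). On this basis compound 4 is estimated at 4500 nM in this assay, with a likely range from 1500 nM to 13000 nM.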

Compound 4, half-maximal inhibitory concentration: 214 nM
Estimate against measurement, compound 4: 21-fold (1.32 log units) above; measured number below the stated range.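

In this assay, oxetan-3-yl in place of isopropyl gave a 2.4-fold lower number from compound 3 to compound 4 (0.37 log units; beyond the scatter), so the change did not keep its direction when carried from the core of compound 1 to the core of compound 3: the same change on two cores in this assay, an 11-fold higher number (1.03 log units; beyond the scatter) from compound 1 to compound 2 and a 2.4-fold lower number (0.37 log units; beyond the scatter) from compound 3 to compound 4, 25-fold (1.40 log units) apart, beyond the scatter of two such steps
Methyl in place of hydrogen on the aromatic nitrogen likewise did not carry over unchanged, giving a 13-fold lower number from compound 2 to compound 4 (1.11 log units; beyond the scatter): the same change on two cores in this assay, a 1.9-fold higher number (0.28 log units; within the scatter) from compound 1 to compound 3 and a 13-fold lower number (1.11 log units; beyond the scatter) from compound 2 to compound 4, 25-fold (1.40 log units) apart, beyond the scatter of two such steps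
These four compounds show that the two changes do not act independently here, but they do not show why, or how either change would behave on any other core.

Left open is whether the reversal is specific to oxetan-3-yl or would also appear with a cyclobutyl group or a longer chain on that oxygen. Also open, as far as these compounds go, is whether an ethyl group on the aromatic nitrogen would behave like methyl.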